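A few compounds are considered here, and "the series" means these few. Any claim that something is new, unique, unknown or untested is made for them only; others in the source may bear on it.

In a functional assay on cells (Homo sapiens) for cytotoxicity, read by MTT assay, with a stated time of 24 h (a lower number here means a stronger inhibitor, a higher number a weaker inhibitor), three compounds sharing a long chain have been measured so far. Compound 1 `CCCCCCCCCCCCCCNC(=O)[C@H](CO)/N=C/c1ccccc1[N+](=O)[O-]` gives 21700 nM, compound 2 `CCCCCCCCCCCCCCNC(=O)[C@H](CO)/N=C/c1ccccc1OC` gives 12500 nM, and compound 3 `CCCCCCCCCCCCCCNC(=O)[C@H](CO)NCc1ccccc1O` gives 75300 nM. That last number is the highest of the three, which makes compound 3 the weakest inhibitor of the set.

Compound 4 `CCCCCCCCCCCCCCNC(=O)[C@H](CO)/N=C/c1ccc(O)cc1` differs from compound 3 in one place: a group of 9 heavy atoms (7 carbon, 1 nitrogen, 1 oxygen; one six-membered aromatic ring of carbon only) in place of a group of 9 heavy atoms (7 carbon, 1 nitrogen, 1 oxygen; one six-membered aromatic ring of carbon only), on a saturated chain carbon bound to a carbonyl carbon and a saturated chain carbon. The (2-hydroxybenzyl)amino group leaves and a group with no common name enters, on a saturated chain carbon bound to a carbonyl carbon and a saturated chain carbon. The entering group has a double bond outside aromatic rings, as do the matching groups of compound 1 and compound 2.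

The measured step closest to this change is a 6.0-fold higher number from compound 2 to compound 3 (0.78 log units; beyond the scatter). It loses that double bond, whereas the new change regains it, so the number is expected to move the opposite way. Going by the values given here, the other measured step, a 1.7-fold lower number from compound 1 to compound 2 (0.24 log units; within the scatter), shows that methoxy in place of nitro on an aromatic carbon made no clear difference, although no measured compound tests the hydroxy group of compound 4 directly.

The expected step is a 4.4-fold lower number from compound 3 to compound 4 (0.65 log units; beyond the scatter). For compound 4 the estimated value is 17000 nM, with an expected range from 7000 nM to 42000 nM.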

Compound 4, half-maximal inhibitory concentration: 19300 nM
Beside the measured number, compound 4's estimate is 1.1-fold (0.06 log units) below it; low and high end bracket the measured number.
By their numbers in this assay, from the lowest: compounds 2, 4 and 1 (each within the scatter of the next); then compound 3.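

In this assay, replacing the (2-hydroxybenzyl)amino group with the group that carries the double bond gives a 3.9-fold lower number from compound 3 to compound 4 (0.59 log units; beyond the scatter), so a hydroxy group on the ring does not by itself go with the high number of compound 3. On the carbon with a double bond to nitrogen, the ring groups shown cannot be told apart: 4-hydroxyphenyl in place of 2-methoxyphenyl gives a 1.5-fold higher number from compound 2 to compound 4 (0.19 log units; within the scatter) and 4-hydroxyphenyl in place of 2-nitrophenyl gives a 1.1-fold lower number from compound 1 to compound 4 (0.05 log units; within the scatter), and so all three compounds with this double bond now sit together, clear of compound 3. Nothing available here explains why these numbers fall as they do.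

Between compound 3 and compound 4, the double bond and the ring group change together, so the share of each in the step stays open, and a 2-hydroxyphenyl group on the carbon with a double bond to nitrogen would separate the two. Going by these compounds alone, also open is whether a 4-aminophenyl group in that place, or a longer chain than the one all four compounds share, would move the number beyond the scatter.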